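The compounds below may be only part of what the source reports. "The series", "measured", "known", "first", "only" and "open" are said of these compounds alone.

Measured in a physicochemical assay for lipophilicity, using the shake flask method, measured as octanol-water partition, at pH 7.4; a lower number here means a more polar compound, a higher number a more lipophilic compound:

- Compound 1 `CC(=O)N[C@H]1[C@H]([C@@H](O)[C@H](O)CNC(=O)c2ccc(Cl)cc2)O[C@@](OCc2ccc(F)cc2)(C(=O)O)C[C@@H]1O`: -0.11
- Compound 2 `CC(=O)N[C@H]1[C@H]([C@@H](O)[C@H](O)CNC(=O)c2ccc(Cl)cc2)O[C@@](OCc2cccc(Cl)c2Cl)(C(=O)O)C[C@@H]1O`: 0.53

Of these two, compound 2 stands higher, at 0.53. Compound 3 `CC(=O)N[C@H]1[C@H]([C@@H](O)[C@H](O)CNC(=O)c2ccc(Cl)cc2)O[C@@](OCc2cccc(F)c2F)(C(=O)O)C[C@@H]1O` has not yet been measured. It differs from compound 2 by one change: 2,3-difluorophenyl in place of 2,3-dichlorophenyl on a saturated chain carbon bound to an oxygen on a saturated carbon. Here 2,3-difluorophenyl takes the place of 2,3-dichlorophenyl on a saturated chain carbon bound to an oxygen on a saturated carbon.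

For the measured compounds named here, only one measured step bears on this change: a number 0.64 log units higher from compound 1 to compound 2 (beyond the scatter). That modest step brought in 2,3-dichlorophenyl in place of 4-fluorophenyl. Compound 3 gives up the chlorines and carries fluorine instead, as does compound 1 at -0.11, so most of that step is expected to be undone, downward and beyond the scatter. The expected change is a number 0.45 log units lower from compound 2 to compound 3 (beyond the scatter). The estimate for compound 3 is 0.08, with an expected range from -0.22 to 0.38.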

Compound 3, distribution coefficient: -0.27
Compound 3: middle estimate off by 0.35 log units, on the high side; the whole stated range lies above it.
By their numbers in this assay, from the lowest: compounds 3 and 1 (each within the scatter of the next); then compound 2.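

In this assay, exchanging 2,3-dichlorophenyl for 2,3-difluorophenyl on a saturated chain carbon bound to an oxygen on a saturated carbon gives a number 0.80 log units lower from compound 2 to compound 3 (beyond the scatter) and so separates the two halogens within the same named substitution pattern. The other new comparison, 2,3-difluorophenyl in place of 4-fluorophenyl, gives a number 0.16 log units lower from compound 1 to compound 3 (within the scatter) and shows that, among these three compounds, only the group bearing chlorine stands apart from the others. Nothing available here accounts for the size of the step from chlorine to fluorine.

The compounds shown leave open where a 4-chlorophenyl or an unsubstituted phenyl would fall at this place. They also leave open whether a single chlorine would be enough, or whether a phenyl carrying one chlorine and one fluorine would stand with compound 2 or with compound 3.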